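The source may report more compounds than this note shows. Statements on the series, on what has been measured and on what is new or still open speak of the compounds shown alone.

Values so far in an ADME assay on the whole organism (Rattus norvegicus, strain Sprague-Dawley) for pharmacokinetics, read by LC-MS, at a dose of 10 mg/kg by the oral route; a lower number here means less compound in the circulation, a higher number more compound in the circulation at the dose given

- compound 1 `COc1ccc(F)c([C@H]2CC[C@H](COc3cccc([C@@H](CC(=O)O)C4CC4)c3)CC2)c1` gives 42700 nM
- compound 2 `COc1ccc(F)c([C@H]2CC[C@H](COc3cccc([C@H](C4CC4)[C@H](C)C(=O)O)c3)CC2)c1` gives 3080 nM

Compound 2 holds the lower of these two numbers, and the gap lies beyond the scatter. Compound 3 `COc1ccc(F)c([C@H]2CC[C@H](COc3cccc([C@H](C4CC4)[C@@H](F)C(=O)O)c3)CC2)c1` has not been measured yet and differs from compound 2 in one place carboxy(fluoro)methyl in place of 1-carboxyethyl on a saturated chain carbon bound to an aromatic carbon and a saturated ring carbon while the rest of the structure stays the same. Within the data shown here, only one measured step bears on this change, and it is large: a 14-fold lower number from compound 1 to compound 2 (1.14 log units; beyond the scatter) for methyl in place of hydrogen. Among the measured compounds shown here, that methyl is gone again in compound 3, but a fluoro group stands in its stead, and no measured compound carries one. A partial return towards compound 1 (42700 nM) is therefore expected, not a full one. The expected change is a 2.9-fold higher number from compound 2 to compound 3 (0.47 log units; beyond the scatter) as a moderate move to a higher number. For compound 3 the estimate is 9000 nM (expected range 2500 nM to 35000 nM).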

Compound 3, maximal plasma concentration: 8320 nM
The estimate for compound 3 lay 1.1-fold (0.03 log units) above the measured number; the measured number falls inside the stated range.
By their numbers in this assay, from the lowest: compound 2; then compound 3; then compound 1.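

On the saturated chain carbon bound to a carbonyl carbon and a saturated chain carbon, this assay can now be compared across three substituents: hydrogen, methyl and fluoro. Carboxy(fluoro)methyl in place of 1-carboxyethyl gives a 2.7-fold higher number from compound 2 to compound 3 (0.43 log units; beyond the scatter), whereas fluoro in place of hydrogen gives a 5.1-fold lower number from compound 1 to compound 3 (0.71 log units; beyond the scatter). Fluoro therefore places compound 3 between the other two, so the low number is not unique to methyl, although methyl has the larger effect; no measurement shown here explains this order.

From the compounds shown here alone, whether the same order would hold with other substituents at this carbon remains open, such as a hydroxyl group, an ethyl chain or a second fluorine. The compounds shown also leave open whether the order would persist with another change elsewhere in the shared core.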